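Fluoro for Methyl: Expectation for Compound 4

The compounds below may be only part of what the source reports. "The series", "measured", "known", "first", "only" and "open" are said of these compounds alone.

Compound 1 `C#CCn1c(=O)c(C=O)cc2cc(F)ccc21` and compound 2 `C#CCn1c(=O)c(C=O)cc2cc(C)ccc21` are the two aldehydes of the set. In a functional assay on NCI-H460 cells (Homo sapiens) for cytotoxicity, read by MTT assay, with a stated time of 24 h (a higher number here means a weaker inhibitor, a lower number a stronger inhibitor), compound 1 gives only a limit, > 100000 nM. Compound 2 likewise gives only a limit, > 100000 nM. The step that the two limits leave unreadable from compound 2 to compound 1, made by the change (fluoro in place of methyl on an aromatic carbon), cannot be sized because of the limit of > 100000 nM in this assay, at which 2 of the 3 values shown sit. Compound 3 `C#CCn1c(=O)c(/C=C/C(=O)/C=C(O)/C=C/c2ccc(O)c(OC)c2)cc2cc(C)ccc21` carries a far larger side chain in place of the aldehyde; how its core differs from that of compound 2 is not broken down here. In this assay, going by the values given here, compound 3 gives 21800 nM, the only number among the three. Compound 4 `C#CCn1c(=O)c(/C=C/C(=O)/C=C(O)/C=C/c2ccc(O)c(OC)c2)cc2cc(F)ccc21` repeats the same kind of change, (fluoro in place of methyl on an aromatic carbon), on compound 3. The measured pair gives no size for this change. The expected step is therefore small, a 1.1-fold higher number from compound 3 to compound 4 (0.06 log units; within the scatter). Compound 4 is expected near 25000 nM, between 8000 nM and 70000 nM.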

Compound 4, half-maximal inhibitory concentration: 44300 nM
Compound 4: middle estimate off by 1.8-fold (0.25 log units), on the low side, and the stated range covers the measured number.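

In this assay, fluoro in place of methyl on an aromatic carbon gives a 2.0-fold higher number from compound 3 to compound 4 (0.31 log units; beyond the scatter), so the change has a readable, modest size on the core of compound 3. The same change from compound 2 to compound 1 cannot be read, so no second size stands beside this one: the limit of > 100000 nM in this assay, at which 2 of the 4 values shown sit. The series therefore shows the change on one core only and does not show that its size carries from one core to another.

The compounds shown leave open whether chloro, methoxy or trifluoromethyl on the same aromatic carbon would give a similar step. They also leave open how an amine or a carboxylic acid there would move the number.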